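Dimethoxyphenyl change from compound 2 to compound 4

The compounds below may be only part of what the source reports. "The series", "measured", "known", "first", "only" and "open" are said of these compounds alone.

In a functional assay on SW480 cells (Homo sapiens) for cytotoxicity, read by sulforhodamine B assay, with a stated time of 48 h (on this read-out lower numbers stand for stronger inhibition and higher numbers for weaker inhibition), compound 2 `COc1ccc(-c2cc(C(=O)/C=C/c3cccc(OC)c3OC)ccc2N)cc1OC` gives 8330 nM as the reference point for this step. Compound 3 `O=C(/C=C/c1cccc(-c2ccc(F)cc2)c1)c1ccc(O)cc1` at 12000 nM lies within the scatter of compound 2, while compound 1 `COc1cc(/C=C/C(=O)c2ccc(N)c(-c3ccc(F)cc3)c2)cc(Br)c1O` at 22900 nM reads higher than compound 2, beyond the scatter.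

Compound 4 `COc1ccc(/C=C/C(=O)c2ccc(N)c(-c3ccc(OC)c(OC)c3)c2)c(OC)c1` differs from compound 2 by 2,4-dimethoxyphenyl in place of 2,3-dimethoxyphenyl on a double-bonded chain carbon bound to a double-bonded chain carbon with 2,4-dimethoxyphenyl in place of 2,3-dimethoxyphenyl on a double-bonded chain carbon bound to a double-bonded chain carbon. Within the data shown here, no measured pair differs in one place, so the data show no direct precedent and favour no direction. The estimated step of a 1.1-fold higher number from compound 2 to compound 4 (0.03 log units; within the scatter) is expected to stay within the scatter in this assay for this series. Compound 4 is expected at 9000 nM with an estimated range from 4000 nM to 20000 nM on this read-out.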

Compound 4, half-maximal inhibitory concentration: 9300 nM
For compound 4 the middle estimate is 1.0-fold (0.01 log units) below the measured one, and the stated range covers the measured number.
By their numbers in this assay, from the lowest: compounds 2, 4, 3 and 1 (each within the scatter of the next, the first and the last beyond it).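

In this assay, the step of a 1.1-fold higher number from compound 2 to compound 4 (0.05 log units; within the scatter) gives the series its first pair that differs in one place, and it lies within the scatter. On a double-bonded chain carbon bound to a double-bonded chain carbon, 2,4-dimethoxyphenyl and 2,3-dimethoxyphenyl, which have the same atoms joined differently, are therefore not told apart by this read-out. The compounds shown leave open whether a carboxylic acid or a morpholine at this place would give a step beyond the scatter. No accompanying measurement bears on this result.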